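This account rests on a few compounds, and the source may have more. Where it says the series, first, only, none or still open, it means among the compounds named here.

Compound 1 `Cc1c(OCCCCOc2ccccc2C(=O)O)ccc(C(=O)CC2CCCC2)c1C` gives 28% in an assay on HEK293 cells for positive allosteric modulation of metabotropic glutamate receptor 3 (Rattus norvegicus), read by thallium flux, with a stated time of 2.5 min; a lower number here means a smaller maximal response, a higher number a larger maximal response. Compound 2 `Cc1c(OCCCCOc2ccc(F)c(C(=O)O)c2)ccc(C(=O)CC2CCCC2)c1C` differs by 3-carboxy-4-fluorophenyl in place of 2-carboxyphenyl on an oxygen on a saturated carbon and gives 12.6%, the step being a number 15.4 percentage points lower from compound 1 to compound 2 (beyond the scatter). The core of compound 3 `Cc1c(OCCCCOc2ccccc2C(=O)O)ccc(C(=O)CC(C)C)c1O` differs from that of compound 1 in a way not broken down here, and compound 3 gives 28.1%; its value and that of compound 1 lie within the scatter of each other, while compound 2 sits beyond the scatter from both. Compound 4 `Cc1c(OCCCCOc2ccc(F)c(C(=O)O)c2)ccc(C(=O)CC(C)C)c1O` is not yet measured and differs from compound 3 by 3-carboxy-4-fluorophenyl in place of 2-carboxyphenyl on an oxygen on a saturated carbon, the same change that separates compound 1 from compound 2. Going by the values given here, for compound 4 a step of a number 15.1 percentage points lower from compound 3 to compound 4 (beyond the scatter) in this assay is expected, beside the earlier one, because a number 15.4 percentage points lower from compound 1 to compound 2 (beyond the scatter) is the only precedent for this change. The estimate for compound 4 in this assay is therefore 13%, expected between 5% and 23%.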

Compound 4, largest response reached (reported as percent of maximum), in percent of the reference or control that the assay uses: 81.7%
Estimate against measurement, compound 4: 68.7 percentage points below; the measured number lies above the stated range.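

In this assay the change to 3-carboxy-4-fluorophenyl gives a number 53.6 percentage points higher from compound 3 to compound 4 (beyond the scatter), so neither the direction nor the size of the step carries from one core to the other: the same change on two cores in this assay, a number 15.4 percentage points lower (beyond the scatter) from compound 1 to compound 2 and a number 53.6 percentage points higher (beyond the scatter) from compound 3 to compound 4, 69 percentage points apart, beyond the scatter of two such steps

The effect of this change therefore depends on the core, at least for the core of compound 1 and the core of compound 3. These two pairs do not show which difference between the cores is responsible, and they give no rule for a third core.

From the compounds shown here alone, it remains open which part of the core sets the direction of the step. Going by these compounds, it is also open how a chlorine in place of the fluorine, or a tetrazole in place of the carboxylic acid, would behave on either core.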